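The source may hold more compounds than are shown below. What is called first, only, known or untested is meant among the compounds shown, and "the series" means these compounds.

Measured compounds and their values:
- compound 1 `CC(C)COC(=O)Nc1ccc([Se]C#N)cc1` gives 38300 nM
- compound 2 `Cc1ccc(OC(=O)Nc2ccc([Se][Se]c3ccc(NC(=O)Oc4ccc(C)cc4)cc3)cc2)cc1` gives 48500 nM
- compound 3 `O=C(Nc1ccc([Se][Se]c2ccc(NC(=O)Oc3ccccc3)cc2)cc1)Oc1ccccc1` gives 48100 nM

All three numbers come from a functional assay on CCRF-CEM cells (Homo sapiens) for cytotoxicity, read by MTT assay, with a stated time of 72 h; on this read-out lower numbers stand for stronger inhibition of growth and higher numbers for weaker inhibition of growth. Compound 1 carries a selenocyanate on its core, while compound 2 and compound 3 are diselenides built from two such aryl units. On the numbers shown, compound 1 sits alongside compound 2 and compound 3: the gaps between its value and each of theirs lie within the usual scatter of this assay, so the three cannot be told apart on this read-out.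

Compound 4 `N#C[Se]c1ccc(NC(=O)OCc2ccccc2)cc1` has not been measured in this assay. It differs from compound 1 in one place: phenyl in place of isopropyl on a saturated chain carbon bound to an oxygen next to a carbonyl group. Going by the values given here, no step between measured compounds mirrors this change, so there is nothing in the data to set its size or direction. Given that, the step is expected to be none beyond the scatter, with a 1.1-fold lower number from compound 1 to compound 4 (0.03 log units; within the scatter) as the expected step. Compound 4 is estimated at 36000 nM, with a range from 15000 nM to 85000 nM.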

Compound 4, concentration for total growth inhibition: 48400 nM
Beside the measured number, compound 4's estimate is 1.3-fold (0.13 log units) below it; the range from low to high includes it.
By their numbers in this assay, from the lowest: compounds 1, 3, 4 and 2 (each within the scatter of the next).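

Phenyl in place of isopropyl on a saturated chain carbon bound to an oxygen next to a carbonyl group gives the first step that can be read in this assay, with a 1.3-fold higher number from compound 1 to compound 4 (0.10 log units; within the scatter). This position therefore accepts a six-membered aromatic ring of carbon only in place of a smaller open group, with both compounds carrying the selenocyanate, and the two cannot be told apart on this read-out. Nothing available explains why the two groups read alike.

On these data alone, whether an amine, a carboxylic acid or a longer chain at this same carbon would produce a step beyond the scatter remains open. So does whether the exchange of phenyl for isopropyl would read the same way in a diselenide.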